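Swapping isobutyl for phenyl on the ester side chain

A few compounds are considered here, and "the series" means these few. Any claim that something is new, unique, unknown or untested is made for them only; others in the source may bear on it.

For the measured compounds named here, in a functional assay on the whole organism (arterial blood) with Rattus norvegicus as the target (on this read-out higher numbers stand for an effect only at larger amounts of compound and lower numbers for an effect already at smaller amounts), compound 1 `Cc1nc2cnccc2n1CC1CCN(C(=O)N[C@H](C)c2ccccc2)CC1` gives 0.017 mg/kg and compound 2 `CCOC(=O)[C@H](CC(C)C)NC(=O)N1CCC(Cn2c(C)nc3cnccc32)CC1` gives 0.03 mg/kg, so compound 2 stands within the scatter of the only other measured number. The next structure, compound 3 `CCOC(=O)[C@@H](NC(=O)N1CCC(Cn2c(C)nc3cnccc32)CC1)c1ccccc1`, has phenyl in place of isobutyl on a saturated chain carbon bound to an amide-type nitrogen and a carbonyl carbon.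

Going by the values given here, no measured step makes this exchange directly. The nearest evidence is a 1.8-fold higher number from compound 1 to compound 2 (0.25 log units; within the scatter), where 1-(ethoxycarbonyl)-3-methylbutyl replaces 1-phenylethyl on an amide-type nitrogen. That step stays within the scatter of this assay, and it shows that a substituent with phenyl and one with isobutyl and the ester can give values that are not distinguishable. With a single step as support, the expectation is uncertain, and no shift beyond the scatter is predicted in either direction.

The expected change is no change at the digits printed from compound 2 to compound 3 (within the scatter). For compound 3 the estimated value is 0.03 mg/kg, with an expected range from 0.01 mg/kg to 0.09 mg/kg.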

Compound 3, dose for 50% inhibition: 0.061 mg/kg
Compound 3: the middle estimate sits 2.0-fold (0.31 log units) below what was measured; measured number inside the range.
By their numbers in this assay, from the lowest: compounds 1 and 2 (each within the scatter of the next); then compound 3.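

Working notes: in this assay, phenyl in place of isobutyl on a saturated chain carbon bound to an amide-type nitrogen and a carbonyl carbon gives a 2.0-fold higher number from compound 2 to compound 3 (0.31 log units; beyond the scatter) and so makes this the first exchange in the series to pass the scatter, which the earlier step between compound 1 and compound 2 did not do. Ethoxycarbonyl in place of methyl on the carbon bearing phenyl gives a 3.6-fold higher number from compound 1 to compound 3 (0.55 log units; beyond the scatter) as a second step beyond the scatter, so with phenyl held on this carbon, the exchange of methyl for the ester also moves the number upward. Both shifts are modest, and no measurement at hand gives a reason for either of them.

Still open, on these data alone, is whether the ester itself is needed at this carbon, which a carboxylic acid or a primary amide in place of ethoxycarbonyl would test with either side chain. Also open, as far as these compounds go, is how the number responds to other groups in place of isobutyl or phenyl, such as benzyl, cyclohexyl or a plain methyl with the ester kept.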